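The source may report more compounds than this note shows. Statements on the series, on what has been measured and on what is new or still open speak of the compounds shown alone.

The measured compounds:
Compound 1, `CCC1(Cc2ccccc2)OS(=O)(=O)C=C1OCC(=O)OC`. In an ADME assay on HEL cells (Homo sapiens) for cytotoxicity, with a stated time of 3 days (on this read-out higher numbers stand for lower toxicity in this test and lower numbers for higher toxicity in this test), compound 1 gives > 400000 nM, which is a limit of the assay and not a number.
Compound 2, `CCC1(Cc2ccccc2)OS(=O)(=O)C=C1OS(=O)(=O)c1ccc(C)cc1`. In this assay compound 2 gives 400000 nM.
Compound 3, `CCC1(Cc2ccccc2)OS(=O)(=O)C=C1OCc1ccccc1Cl`. In this assay compound 3 gives >= 20000 nM, which is again a limit of the assay and not a number.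

Compound 3 thus stands only as a limit in this assay, and of the two other values shown, one is also a limit, so only compound 2 supplies a plain number. A single measured step joins compounds that differ in one place: a step that the two limits leave unreadable from compound 1 to compound 3. Its size cannot be read because the limit of > 400000 nM in this assay, at which 1 of the 3 values shown sits, and the limit of >= 20000 nM in this assay, at which 1 of the 3 values shown sits, bound both of its ends.

Compound 4, `CCC1(Cc2ccccc2)OS(=O)(=O)C=C1OCc1ccc(Cl)c(Cl)c1`, differs from compound 3 by 3,4-dichlorophenyl in place of 2-chlorophenyl on a saturated chain carbon bound to an oxygen on an unsaturated carbon. Among the compounds with values here, no measured step exchanges one chlorinated ring for another, so nothing among the measured compounds speaks directly to this change, and the one step that does exist is unreadable. Compound 4 is therefore expected to stand near compound 3, with a number no higher from compound 3 to compound 4 (the limit leaves the size open) expected to lie within the scatter. The estimate for compound 4 in this assay is 20000 nM, between 5000 nM and 100000 nM.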

Compound 4, minimum cytotoxic concentration: >= 20000 nM
Compound 4 gave a limit, no number; the forecaster's own chance of this, stated with the estimate: 60%; the middle value sits exactly at the limit.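

Compound 1, compound 3 and compound 4 all stand only as limits in this assay, and the steps from compound 3 to compound 4 and from compound 1 to compound 4 cannot be read. The compounds shown leave open whether 3,4-dichlorophenyl in place of 2-chlorophenyl changes the minimum cytotoxic concentration at all.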